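Trifluoromethyl Hydrate Chain Probes Histone Deacetylase 8

This account rests on a few compounds, and the source may have more. Where it says the series, first, only, none or still open, it means among the compounds named here.

Compound 1 `COc1ccc(NC(=O)CCCCCCNC(=O)C(O)(O)C(F)(F)F)cc1` and compound 2 `COc1ccc2sc(NC(=O)CCCCCCNC(=O)C(O)(O)C(F)(F)F)nc2c1` share the same chain and differ only in the aryl group at its end. In an assay on isolated protein for inhibition of histone deacetylase 8 (Homo sapiens), read by chemiluminescence, with a stated time of 3 h (a higher number here means a weaker inhibitor, a lower number a stronger inhibitor), compound 1 gives 51000 nM. In this assay compound 2 gives 8900 nM, the lowest of the two numbers shown, and its gap to compound 1 lies beyond the scatter. Compound 3 `O=C(CCCCCCNC(=O)C(O)(O)C(F)(F)F)Nc1nc2ccccc2s1` carries the change (hydrogen in place of methoxy on an aromatic carbon). Among the measured compounds shown here, no measured pair shows this change, so in this assay only a modest step is expected, toward a slightly higher number or none beyond the scatter. Compound 3 is estimated at 12000 nM, between 4500 nM and 32000 nM, which is expected to mean a step of a 1.3-fold higher number from compound 2 to compound 3 (0.13 log units; within the scatter).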

Compound 3, half-maximal inhibitory concentration: 5300 nM
The estimate for compound 3 lay 2.3-fold (0.35 log units) above the measured number; the measured number falls inside the stated range.
By their numbers in this assay, from the lowest: compounds 3 and 2 (each within the scatter of the next); then compound 1.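

Replacing methoxy with hydrogen on an aromatic carbon gives a 1.7-fold lower number from compound 2 to compound 3 (0.23 log units; within the scatter) in this assay, so the methoxy group is not needed there to hold this level of inhibition. With 1,3-benzothiazol-2-yl in place of 4-methoxyphenyl on an amide-type nitrogen, the same assay gives a 9.6-fold lower number from compound 1 to compound 3 (0.98 log units; beyond the scatter) and thus isolates the effect of the aryl group without a methoxy group on either side of the comparison. Nothing available explains either step.

On these data alone, it remains open whether an amine or a chlorine atom on that aromatic carbon would move the number beyond the scatter. As far as these compounds go, the effect of a longer chain also remains open.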